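The source may hold more compounds than are shown below. What is called first, only, known or untested is meant among the compounds shown, and "the series" means these compounds.

Measured compounds in this study:

compound 1, `COc1ccc(Sc2ccccc2N2CC(C)N(CC(=O)O)CC2C)cc1` — 580 nM
compound 2, `COc1ccc(Sc2ccccc2N2C[C@H](C)N(CC(=O)O)C[C@@H]2C)cc1` — 18000 nM
compound 3, `COc1ccc(Sc2ccccc2N2CCN(CC(=O)O)CC2C)cc1` — > 10000 nM

All three were tested in an assay for inhibition of sodium- and chloride-dependent glycine transporter 1 (Homo sapiens); a lower number here means a stronger inhibitor, a higher number a weaker inhibitor. The value given for compound 3 is a limit of the assay, not a number (the limit of > 10000 nM in this assay, at which 1 of the 3 values shown sits). Compound 3 therefore stands at the weak end of the values shown, with only a limit to mark its place.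

Compound 4, `COc1ccc(Sc2ccccc2N2CCN(CC(=O)O)CC2)cc1`, differs from compound 3 by hydrogen in place of methyl on a saturated ring carbon. The same kind of change has been measured once before: an at least 17-fold higher number from compound 1 to compound 3 (1.23 log units; beyond the scatter). The other measured step, a 31-fold higher number from compound 1 to compound 2 (1.49 log units; beyond the scatter), is of a different kind and rests on (the fact that one of compounds 1 and 2 is drawn with a defined configuration and the other without, at the place where they differ), so it says nothing directly about removing a methyl group.

Within the data shown here, the one comparable step was large and went toward a weaker inhibitor, and compound 3 already sits at the limit of the assay. Taking away the remaining methyl group is therefore expected to leave compound 4 at the limit or beyond it, so that the step that the limit leaves unreadable from compound 3 to compound 4 is expected to be small or unreadable rather than a gain. Compound 4 is expected to give 20000 nM, within a range from 5000 nM to 80000 nM, and most probably the assay will again report only a limit.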

Compound 4, half-maximal inhibitory concentration: > 10000 nM
Compound 4: a limit, no number; the forecaster's own chance of this, stated with the estimate: 70%; the middle value does not contradict the limit.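

Compound 3 and compound 4 both reach only a limit and give no number, so the step between them cannot be read in this assay: the limit of > 10000 nM in this assay, at which 2 of the 4 values shown sit.

The compounds shown leave open whether replacing the methyl group of compound 3 with hydrogen changes inhibition at all, and which of compound 3 and compound 4 is the stronger inhibitor.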